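The source may hold more compounds than are shown below. What is called first, only, known or untested is meant among the compounds shown, and "the series" means these compounds.

Measured in a physicochemical assay for solubility, measured as kinetic solubility; a higher number here means a more soluble compound, a lower number a less soluble compound:
- compound 1 `Cc1ccc(NC(=O)c2cc(Oc3cnc(C(=O)N(C)C)cn3)c3cc(C)oc3c2)nc1`: 215000 nM
- compound 2 `Cc1cc2c(Oc3cnc(C(=O)N(C)C)cn3)cc(C(=O)Nc3cnccn3)cc2o1`: 30000 nM
- compound 3 `COc1cnc(NC(=O)c2cc(Oc3cnc(C(=O)N(C)C)cn3)c3cc(C)oc3c2)cn1`: 25000 nM

Compound 3 stands at 25000 nM. Its nearest neighbour on the numbers is close: a 1.2-fold lower number from compound 2 to compound 3 (0.08 log units; within the scatter). Its furthest is clearly separated: an 8.6-fold lower number from compound 1 to compound 3 (0.93 log units; beyond the scatter).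

The next compound is compound 4 `Cc1cc2c(Oc3cnc(C(=O)N(C)C)cn3)cc(C(=O)Nc3cnc(C(F)(F)F)cn3)cc2o1`, which carries trifluoromethyl in place of methoxy on an aromatic carbon. The same difference reads as 5-methoxypyrazin-2-yl to 5-(trifluoromethyl)pyrazin-2-yl.

Going by the values given here, three measured steps bear on this. The one at the same place, methoxy in place of hydrogen, is a 1.2-fold lower number from compound 2 to compound 3 (0.08 log units; within the scatter), so that substitution moved the number very little. The two larger steps, a 7.2-fold lower number from compound 1 to compound 2 (0.86 log units; beyond the scatter) and an 8.6-fold lower number from compound 1 to compound 3 (0.93 log units; beyond the scatter), replace the whole 5-methylpyridin-2-yl group and are modest. Among the compounds with values here, no measured compound carries trifluoromethyl, so the direction rests on judgement alone. A small downward move is expected, and a result within the scatter of compound 3 would not surprise.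

The estimated step is a 1.8-fold lower number from compound 3 to compound 4 (0.25 log units; within the scatter). For compound 4 the expected value in this assay is 14000 nM, with an expected range of 3500 nM to 35000 nM.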

Compound 4, solubility: 6000 nM
Compound 4: middle estimate off by 2.3-fold (0.37 log units), on the high side, and the stated range covers the measured number.
By their numbers in this assay, from the lowest: compound 4; then compounds 3 and 2 (each within the scatter of the next); then compound 1.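

Notes on the position: in this assay this aromatic carbon is not indifferent to what it carries, since methoxy had stayed within the scatter of hydrogen, whereas trifluoromethyl gives a 4.2-fold lower number from compound 3 to compound 4 (0.62 log units; beyond the scatter) and a 5.0-fold lower number from compound 2 to compound 4 (0.70 log units; beyond the scatter) in the same series. Going by these compounds alone, exchanging the whole 5-methylpyridin-2-yl group for 5-(trifluoromethyl)pyrazin-2-yl gives a 36-fold lower number from compound 1 to compound 4 (1.55 log units; beyond the scatter) and is the only large step so far, and compound 4 now has the lowest number, with its steps to all three other compounds printed as beyond the scatter. No measurement bearing on the reason for these steps is available, so the notes can record their size but not their origin.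

From the compounds shown here alone, with only hydrogen, methoxy and trifluoromethyl at this carbon, it remains open whether the drop is particular to trifluoromethyl, and a methyl, a chlorine, a nitrile or an amine at the same place would show how general it is. The large step also changes both the ring and its substituent, so the share of each remains unresolved, and the matching 5-(trifluoromethyl)pyridin-2-yl amide would separate the two.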